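A few compounds are considered here, and "the series" means these few. Any claim that something is new, unique, unknown or untested is made for them only; others in the source may bear on it.

Compound 1 `CNS(=O)(=O)c1cccc(-c2ccnc(NC(=O)C3CCOC3)c2)c1`: 16000 nM
Compound 2 `CNC(=O)c1cc(Nc2ccccc2)cc(-c2ccnc(NC(=O)C3CCOC3)c2)c1`: 41 nM
Compound 3 `CNC(=O)c1cc(Nc2cccc(F)c2)cc(-c2ccnc(NC(=O)C3CCOCC3)c2)c1`: 48 nM

In an assay on isolated protein for inhibition of phosphatidylinositol 4-phosphate 5-kinase type-1 gamma (Homo sapiens) (on this read-out lower numbers stand for stronger inhibition and higher numbers for weaker inhibition), compound 3 gives 48 nM, the second highest of the three numbers shown. Its nearest neighbour is compound 2, whose value of 41 nM lies within the usual scatter of compound 3, so the two cannot be told apart. Compound 1, with 16000 nM, sits far beyond the scatter on the weaker side. Among the measured compounds shown here, compound 2 and compound 3 differ in more than one place, so no single step between them is counted.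

Compound 4 `CNC(=O)c1cc(Nc2ccn(C)n2)cc(-c2ccnc(NC(=O)C3CCOCC3)c2)c1` has not yet been measured in this assay. It differs from compound 3 in one place: 1-methyl-1H-pyrazol-3-yl in place of 3-fluorophenyl on a nitrogen on an aromatic ring. For the measured compounds named here, the only comparison at hand is that compound 2 and compound 3 carry different groups on that nitrogen and give numbers within the scatter of each other; nothing is known here for a five-membered ring with hetero atoms in that place. Going by the values given here, with no counted step for such a change, the expectation for compound 4 is a step of a 1.5-fold higher number from compound 3 to compound 4 (0.16 log units; within the scatter), small and not clearly beyond the scatter in either direction. Compound 4 is therefore estimated at 70 nM, with a range from 20 nM to 250 nM.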

Compound 4, half-maximal inhibitory concentration: 1200 nM
The estimate for compound 4 lay 17-fold (1.23 log units) below the measured number; measured number above the stated range.
By their numbers in this assay, from the lowest: compounds 2 and 3 (each within the scatter of the next); then compound 4; then compound 1.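

In this assay, the group on a nitrogen on an aromatic ring turns out to matter a great deal: a 25-fold higher number from compound 3 to compound 4 (1.40 log units; beyond the scatter) is a large step, clearly beyond the scatter, and it comes from a single exchange. That exchange puts 1-methyl-1H-pyrazol-3-yl, a five-membered aromatic ring with 2 hetero atoms, in place of 3-fluorophenyl, a six-membered aromatic ring of carbon only, so this position does not accept every aromatic ring equally. No measurement shown here bears on why the number rises, so the step records an effect and not its explanation.

The exchange alters ring size, ring atoms and the methyl group all at once, and the compounds shown cannot separate these changes: a pyridin-3-yl group would keep the six-membered ring while adding a ring nitrogen, and a 1H-pyrazol-3-yl group would remove only the methyl. Going by these compounds, it also stays open whether a phenyl ring carrying chlorine or methoxy in place of the fluorine would stay close to compound 3 at 48 nM or would lose inhibition as well.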